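Ethoxy to Bromo: Estimating Compound 4 in the Assay

This account rests on a few compounds, and the source may have more. Where it says the series, first, only, none or still open, it means among the compounds named here.

compound 1 `Cc1ccc2c(c1)C(=O)/C(=C/c1ccc(F)cc1)CN2CC(=O)O`: 16.1%
compound 2 `COc1cccc(/C=C2\CN(CC(=O)O)c3ccc(C)cc3C2=O)c1`: 14.4%
compound 3 `CCOc1ccc(/C=C2\CN(CC(=O)O)c3ccc(C)cc3C2=O)cc1`: 25.8%

In an assay on HL-60 cells for inhibition of glutathione S-transferase P (Homo sapiens), read by spectrophotometry, tested at 20 uM (on this read-out higher numbers stand for more inhibition at the one concentration tested (going by the name of the read-out) and lower numbers for less inhibition), compound 3 gives 25.8%, the highest of the three numbers. The step of a number 9.7 percentage points higher from compound 1 to compound 3 (within the scatter) lies within the scatter, so compound 3 and compound 1 cannot be ordered. Compound 2 gives 14.4%, and that gap to compound 3 is beyond the scatter.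

Compound 4 `Cc1ccc2c(c1)C(=O)/C(=C/c1ccc(Br)cc1)CN2CC(=O)O` differs from compound 3 by bromo in place of ethoxy on an aromatic carbon. Going by the values given here, only the step of a number 9.7 percentage points higher from compound 1 to compound 3 (within the scatter) bears on this change, since it concerns the same aromatic carbon, and it was within the scatter. Compound 4 is therefore expected to fall back toward compound 1, a step of a number 6.8 percentage points lower from compound 3 to compound 4 (within the scatter) that likely stays within the scatter. Compound 4 is estimated at 19%, with a range from 8% to 30%.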

Compound 4, a percentage reported as inhibition, at one concentration (the size of the read-out at that concentration, not a potency): 28.2%
For compound 4 the middle estimate is 9.2 percentage points below the measured one; the measured number falls inside the stated range.
By their numbers in this assay, from the lowest: compounds 2, 1, 3 and 4 (each within the scatter of the next, the first and the last beyond it).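

In this assay, bromo on this aromatic carbon, para to a large group, separates from fluoro (a number 12.1 percentage points higher from compound 1 to compound 4 (beyond the scatter)), which ethoxy did not do. Bromo in place of ethoxy leaves the pair unordered (a number 2.4 percentage points higher from compound 3 to compound 4 (within the scatter)), so one heavy atom here cannot be told from the three of ethoxy. The 4-bromophenyl group also separates from the 3-methoxyphenyl group (a number 13.8 percentage points higher from compound 2 to compound 4 (beyond the scatter)).

Going by these compounds, whether an amine or a carboxylic acid on this carbon would read differently stays open. No measured evidence accounts for these steps.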